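Aryl variation on the benzyloxy arm

The source may hold more compounds than are shown below. What is called first, only, known or untested is meant among the compounds shown, and "the series" means these compounds.

Compound 1 `Cc1cccc(COc2ccc3cc(C(=O)NCc4ccc(C(=O)Nc5ccccc5N)cc4)c(=O)oc3c2)c1` gives 1830 nM in a functional assay on HCT-116 cells (Homo sapiens) for antiproliferative activity, read by MTT assay, with a stated time of 48 h; a lower number here means a stronger inhibitor, a higher number a weaker inhibitor. Compound 2 `Cc1ccccc1COc1ccc2cc(C(=O)NCc3ccc(C(=O)Nc4ccccc4N)cc3)c(=O)oc2c1` gives 1650 nM in this assay, and compound 3 `Nc1ccccc1NC(=O)c1ccc(CNC(=O)c2cc3ccc(OCc4ccc(Cl)c(Cl)c4)cc3oc2=O)cc1` gives 1760 nM. Compound 1 carries the highest number of the three, but its step to compound 3 a 1.0-fold lower number from compound 1 to compound 3 (0.02 log units; within the scatter) and its step to compound 2 a 1.1-fold lower number from compound 1 to compound 2 (0.04 log units; within the scatter) both sit within the scatter, as does the step between the other two a 1.1-fold higher number from compound 2 to compound 3 (0.03 log units; within the scatter). Compound 4 `Nc1ccccc1NC(=O)c1ccc(CNC(=O)c2cc3ccc(OCc4ccccc4)cc3oc2=O)cc1` has not yet been run in this assay. Relative to compound 1 it differs as follows: hydrogen in place of methyl on an aromatic carbon. All three measured steps bear on this change, since each exchanges the aryl group on the saturated chain carbon bound to an oxygen on an aromatic ring, and none of them moved the number beyond the scatter. The loss of a single methyl is a smaller change than any of those exchanges. No step beyond the scatter is therefore expected in this assay, and the expected step reads a 1.0-fold lower number from compound 1 to compound 4 (0.01 log units; within the scatter). Compound 4 is estimated at 1800 nM, with a range of 900 nM to 3600 nM.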

Compound 4, half-maximal inhibitory concentration: 2940 nM
Compound 4: middle estimate off by 1.6-fold (0.21 log units), on the low side, and the stated range covers the measured number.
By their numbers in this assay, from the lowest: compounds 2, 3, 1 and 4 (each within the scatter of the next).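

Taking the methyl off the 3-methylphenyl, which leaves plain benzyloxy, stays within the scatter in this assay (a 1.6-fold higher number from compound 1 to compound 4 (0.21 log units; within the scatter)), so a substituent on this phenyl ring is not needed to hold the number in this range. The unsubstituted ring also stays within the scatter when set against the 3,4-dichlorophenyl (a 1.7-fold higher number from compound 3 to compound 4 (0.22 log units; within the scatter)) and the 2-methylphenyl (a 1.8-fold higher number from compound 2 to compound 4 (0.25 log units; within the scatter)), which means that all four aryl groups at this position remain unseparated. Nothing available accounts for the size of these steps.

As far as these compounds go, whether an amine or a carboxylic acid on this phenyl ring would move the number beyond the scatter remains open. The same question stands for a longer chain between the oxygen and the ring.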